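The source may hold more compounds than are shown below. What is called first, only, known or untested is meant among the compounds shown, and "the series" means these compounds.

In a functional assay on MCF7 cells (Homo sapiens) for inhibition, read by MTT assay, with a stated time of 72 h (on this read-out lower numbers stand for stronger inhibition and higher numbers for weaker inhibition), compound 1 `COc1cc2c(Oc3ccc(NC(=O)c4nn(-c5ccccc5F)cc(C)c4=O)cc3)ccnc2cc1OCCCC(=O)NO` gives 2650 nM, compound 2 `COc1cc2c(Oc3ccc(NC(=O)c4nn(-c5ccccc5C)cc(C)c4=O)cc3)ccnc2cc1OCCCCCCC(=O)NO` gives 1830 nM and compound 3 `COc1cc2c(Oc3ccc(NC(=O)c4nn(-c5ccccc5C)cc(C)c4=O)c(F)c3)ccnc2cc1OCCCCCCC(=O)NO` gives 2690 nM. These three values lie within the usual scatter of one another, so compound 3 cannot be separated from either of the other two compounds.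

Compound 4 `COc1cc2c(Oc3ccc(NC(=O)c4nn(-c5ccccc5C)ccc4=O)c(F)c3)ccnc2cc1OCCCCCCC(=O)NO` departs from compound 3 by hydrogen in place of methyl on an aromatic carbon, which is hydrogen in place of methyl on an aromatic carbon. Within the data shown here, no measured step tests this change, since all three measured compounds carry that methyl. The nearest evidence is a 1.5-fold higher number from compound 2 to compound 3 (0.17 log units; within the scatter), a fluoro in place of hydrogen on an aromatic carbon. That step lies at a different place in the structure, so it shows only that one small substitution left the number within the scatter. On this limited basis, no shift beyond the scatter is expected in this assay, and no firm direction can be assigned. The expected step is a 1.1-fold lower number from compound 3 to compound 4 (0.05 log units; within the scatter). The estimated value for compound 4 is 2400 nM, with an expected range from 1000 nM to 5500 nM.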

Compound 4, half-maximal inhibitory concentration: 3650 nM
For compound 4 the middle estimate is 1.5-fold (0.18 log units) below the measured one; the measured number falls inside the stated range.
By their numbers in this assay, from the lowest: compounds 2, 1, 3 and 4 (each within the scatter of the next).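

In this assay, every earlier compound carried the methyl on this six-membered aromatic ring with 2 nitrogen, so compound 4 is the only direct test of this position among those shown. Hydrogen in place of that methyl gives a 1.4-fold higher number from compound 3 to compound 4 (0.13 log units; within the scatter), so the change cannot be told apart from no change at all, and on the structure of compound 3 the number does not depend on this methyl beyond the scatter. No measurement shown here explains this result or assigns any property to the methyl at this position.

The compounds shown leave open whether an ethyl group, a methoxy group or an amine on this aromatic carbon would move the number beyond the scatter. They also leave open whether hydrogen in place of methyl would give a similar result on the structure of compound 2, which has no fluoro.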